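Swapping an Amine Chain for Chlorine on a Quinoline Core

The compounds below may be only part of what the source reports. "The series", "measured", "known", "first", "only" and "open" are said of these compounds alone.

Of the compounds shown here, two have been measured in a functional assay on HepG2 cells (Homo sapiens) for cytotoxicity, read by MTT assay, with a stated time of 48 h; a higher number here means a weaker inhibitor, a lower number a stronger inhibitor. Compound 1 `Clc1ccnc2cc(OCc3ccccc3)ccc12` gives 2680 nM. Compound 2 `CN(C)CCCNc1ccnc2cc(OCc3ccc(F)cc3)ccc12` gives 1570 nM, and its gap to compound 1 falls within the usual scatter, so the two are not distinguishable here. Compound 3 `Fc1ccc(COc2ccc3c(Cl)ccnc3c2)cc1` differs from compound 2 in one place: chloro in place of (3-(dimethylamino)propyl)amino on an aromatic carbon. For the measured compounds named here, no measured pair shows this step, so no direction can be read from the data. Compound 3 is expected near compound 1, because compound 1 also carries a chloro group and gives 2680 nM. The expected step is a 1.6-fold higher number from compound 2 to compound 3 (0.20 log units; within the scatter), with compound 3 estimated at 2500 nM, likely between 1200 nM and 5500 nM.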

Compound 3, half-maximal inhibitory concentration: 3010 nM
For compound 3 the middle estimate is 1.2-fold (0.08 log units) below the measured one; the measured number falls inside the stated range.
By their numbers in this assay, from the lowest: compounds 2, 1 and 3 (each within the scatter of the next).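

In this assay, putting chloro in place of (3-(dimethylamino)propyl)amino opposite the ring nitrogen gives a 1.9-fold higher number from compound 2 to compound 3 (0.28 log units; within the scatter) and so leaves no readable effect of removing the chain. Fluoro in place of hydrogen on an aromatic carbon gives a 1.1-fold higher number from compound 1 to compound 3 (0.05 log units; within the scatter) and is likewise not separable from repeat-measurement noise. Nothing measured here offers an explanation for either result. As far as these compounds go, whether a shorter amine chain, a morpholine or a carboxylic acid at the chloro position would move the number beyond the scatter remains open.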